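The source may hold more compounds than are shown below. What is called first, only, known or untested is meant among the compounds shown, and "the series" means these compounds.

The measured compounds and their values:
- compound 1 `N#Cc1ccc(-c2csc(N/N=C\c3ccco3)n2)cc1` gives 40%
- compound 2 `N#Cc1ccc(-c2csc(N/N=C\c3ccncc3)n2)cc1` gives "not active" (no number reported)
- compound 3 `O=[N+]([O-])c1ccc(-c2csc(N/N=C\c3ccco3)n2)cc1` gives 40%

Going by the values given here, in an in vitro assay on BTI-TN-5B1-4 cells for inhibition of Amine oxidase [flavin-containing] A (Homo sapiens), read by Amplex Red, with a stated time of 15 min, tested at 100 uM (a lower number here means less inhibition, a higher number more inhibition at the concentration tested (going by the name of the read-out)), compound 3 stands level with compound 1 at the digits reported; the one measured step, no change at the digits printed from compound 1 to compound 3 (within the scatter), runs within the scatter. Compound 2, the only other entry, comes without a number and is simply reported as not active.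

Compound 4 `O=[N+]([O-])c1ccc(-c2csc(N/N=C\c3ccncc3)n2)cc1` differs from compound 3 in one place: pyridin-4-yl in place of furan-2-yl on a carbon with a double bond to nitrogen. Among the compounds with values here, no step for this exact change has been measured from compound 3. What bears on it is the pair of compound 1 and compound 2, which differ in the same way on the cyano-bearing core: compound 1 gives 40%, while compound 2 gives "not active" (no number reported). Since the step from compound 1 to compound 3 showed no change, the same replacement on compound 3 is expected to act much as it did on compound 1, that is, to lower inhibition well beyond the scatter.

Compound 4 is therefore estimated at 8%, in the range 0% to 25%, an expected step of a number 32 percentage points lower from compound 3 to compound 4 (beyond the scatter), with a fair chance that only inactivity, and no number, is reported.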

Compound 4, a percentage reported as inhibition, at one concentration (the size of the read-out at that concentration, not a potency): "not active" (no number reported)
Compound 4 has no reported number here; no gap can be computed for the estimate.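

Going by these compounds alone, compound 4, like compound 2, carries no number in this assay, so no step from compound 3 to compound 4, or between compound 2 and compound 4, can be read. No evidence on hand bears on this result. The compounds shown leave open how much inhibition compound 2 and compound 4 retain, and whether nitro in place of cyano matters alongside pyridin-4-yl.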